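This account rests on a few compounds, and the source may have more. Where it says the series, first, only, none or still open, it means among the compounds named here.

In an ADME assay on a cell-free system (plasma, Rattus norvegicus) for metabolic stability, read by LC-MS, with a stated time of 60 min, tested at 100 uM (a higher number here means that more of the compound is left, a lower number that less of the compound is left), compound 1 `Cc1c(OCCCCOc2ccc(C(=O)O)cc2F)ccc(C(=O)CC2CCCC2)c1O` gives 97%, compound 2 `COc1ccc(C(=O)O)cc1OCCCCOc1ccc(C(=O)CC2CCCC2)c(O)c1C` gives 103% and compound 3 `Cc1ccc(C(=O)O)cc1OCCCCOc1ccc(C(=O)CC2CCCC2)c(O)c1C` gives 100%, which places compound 3 within the scatter of both others. Compound 4 `Cc1cc(C(=O)O)ccc1OCCCCOc1ccc(C(=O)CC2CCCC2)c(O)c1C` carries 4-carboxy-2-methylphenyl in place of 5-carboxy-2-methylphenyl on an oxygen on a saturated carbon. For the measured compounds named here, three measured steps bear on this change. Exchanging the carboxy-bearing aryl group gave a number 6 percentage points higher from compound 1 to compound 2 (within the scatter) and a number 3 percentage points higher from compound 1 to compound 3 (within the scatter), while methyl in place of methoxy gave a number 3 percentage points lower from compound 2 to compound 3 (within the scatter). None of these leaves the scatter, so no step beyond it is expected in this assay. The expected step is a number 1 percentage points lower from compound 3 to compound 4 (within the scatter). The estimate for compound 4 is 99%, with an expected range of 90% to 108%.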

Compound 4, percent of the compound remaining: 99%
Compound 4: the middle estimate sits on the measured number at the digits printed; low and high end bracket the measured number.
By their numbers in this assay, from the lowest: compounds 1, 4, 3 and 2 (each within the scatter of the next).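

In this assay, 4-carboxy-2-methylphenyl in place of 5-carboxy-2-methylphenyl on the oxygen gave a number 1 percentage points lower from compound 3 to compound 4 (within the scatter), so joining the same atoms differently at this position leaves the read-out within the scatter. The wider comparisons agree: 4-carboxy-2-methylphenyl in place of 5-carboxy-2-methoxyphenyl gave a number 4 percentage points lower from compound 2 to compound 4 (within the scatter), and methyl in place of fluoro gave a number 2 percentage points higher from compound 1 to compound 4 (within the scatter). Nothing at hand gives a reason for these results. Still open, on these data alone, is how this assay responds to an amide or a tetrazole in place of the carboxylic acid, or to a shorter chain.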